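The source may report more compounds than this note shows. Statements on the series, on what has been measured and on what is new or still open speak of the compounds shown alone.

Measured so far:
compound 1, `CCOC(=O)C1=C(Nc2ccccc2Br)S/C(=C\c2ccc[nH]2)C1=O`: 29.4%
compound 2, `CCOC(=O)C1=C(Nc2ccc(F)cc2)S/C(=C\c2ccc[nH]2)C1=O`: < 10%

In a functional assay on MCF7 cells (Homo sapiens) for inhibition, read by MTT assay, with a stated time of 72 h, tested at 10 uM (on this read-out lower numbers stand for less inhibition and higher numbers for more inhibition at the one concentration tested (going by the name of the read-out)), compound 1 gives 29.4%. For compound 2 the read-out in this assay is a limit of the assay, not a number, < 10%; of the two values in hand, one sits at that limit (the limit of < 10% in this assay, at which 1 of the 2 values shown sits). For the measured compounds named here, the single measured step, a number at least 19.4 percentage points lower from compound 1 to compound 2 (beyond the scatter), shows that exchanging the aryl group on the amine nitrogen can move the read-out beyond the scatter.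

Compound 3, `CCOC(=O)C1=C(Nc2cccc([N+](=O)[O-])c2)S/C(=C\c2ccc[nH]2)C1=O`, is the next member. Its change from compound 2 is 3-nitrophenyl in place of 4-fluorophenyl on an amine nitrogen. Going by the values given here, no measured step bears directly on a 3-nitrophenyl group; the only guidance is that the aryl exchange from compound 1 to compound 2 moved the read-out by at least a modest amount, so a further aryl exchange may again shift it, in either direction, or leave compound 3 at the limit. The expected step is therefore a number at least 5 percentage points higher from compound 2 to compound 3 (that floor lies within the scatter), a modest rise at most, with a substantial chance that only a limit is returned. For compound 3 the estimate in this assay is 15%, within 5% to 35%.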

Compound 3, a percentage reported as inhibition, at one concentration (the size of the read-out at that concentration, not a potency): 27.4%
Estimate against measurement, compound 3: 12.4 percentage points below; measured number inside the range.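

Replacing 4-fluorophenyl with 3-nitrophenyl on the amine nitrogen gives a number at least 17.4 percentage points higher from compound 2 to compound 3 (beyond the scatter) in this assay, so the low reading of compound 2 does not extend to every substituted aryl group at this position. Set against the 2-bromophenyl group, the 3-nitrophenyl group gives a number 2 percentage points lower from compound 1 to compound 3 (within the scatter), so two differently substituted aryl groups read alike here, while the 4-fluorophenyl group of compound 2 goes against any reading of the three as a level series. Compound 2 gives < 10%, which is a limit and not a number, so the step leading from it has a floor but no measured size: the limit of < 10% in this assay, at which 1 of the 3 values shown sits.

The compounds shown do not separate the identity of the aryl substituent from where it sits, and they give no reference reading for the aryl ring without a substituent. A plain phenyl group would supply that reference, and a methoxy-substituted phenyl or a saturated cyclohexyl group on the amine nitrogen would test whether the read-out in this assay depends on the kind of substituent or on the aromatic ring itself.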